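The compounds below may be only part of what the source reports. "The series", "measured", "known", "first", "only" and "open" are said of these compounds alone.

In a functional assay on PC-3 cells (Homo sapiens) for antiproliferative activity, read by WST assay, with a stated time of 3 days (on this read-out higher numbers stand for weaker inhibition and lower numbers for stronger inhibition), compound 1 (`CCCN(CCC)CCCCOc1c(-c2cc(OC)c(OC)c(OC)c2)oc2ccccc2c1=O`) gives 11600 nM and compound 2 (`CCCCN(CCCC)CCCCOc1c(-c2cc(OC)c(OC)c(OC)c2)oc2ccccc2c1=O`) gives 5300 nM as the lower of the two numbers. Compound 3 (`CCCCN(CCCC)CCCCCOc1c(-c2cc(OC)c(OC)c(OC)c2)oc2ccccc2c1=O`) brings the change (dibutylamino)methyl in place of dibutylamino on a saturated chain carbon, four bonds along the chain from an oxygen on an aromatic ring with (dibutylamino)methyl in place of dibutylamino on a saturated chain carbon, four bonds along the chain from an oxygen on an aromatic ring. Going by the values given here, the one measured step, a 2.2-fold lower number from compound 1 to compound 2 (0.34 log units; beyond the scatter) when dibutylamino replaced dipropylamino, is a different change and bears only indirectly. A similarly modest step towards a lower number is therefore expected in this assay with little certainty. The expected step is a 1.3-fold lower number from compound 2 to compound 3 (0.12 log units; within the scatter) on this reasoning. Compound 3 is estimated at 4000 nM (range 1700 nM to 9500 nM).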

Compound 3, half-maximal inhibitory concentration: 6800 nM
Estimate against measurement, compound 3: 1.7-fold (0.23 log units) below; low and high end bracket the measured number.
By their numbers in this assay, from the lowest: compounds 2, 3 and 1 (each within the scatter of the next, the first and the last beyond it).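

In this assay, (dibutylamino)methyl in place of dibutylamino on this saturated chain carbon gives a 1.3-fold higher number from compound 2 to compound 3 (0.11 log units; within the scatter) and so no readable change at this position. Set against dipropylamino, the same group gives a 1.7-fold lower number from compound 1 to compound 3 (0.23 log units; within the scatter) and again stays within the scatter, so compound 3 separates from neither compound 1 nor compound 2, although those two stand apart. Nothing measured here offers an explanation for this result.

The compounds shown leave open whether a longer chain, such as 2-(dibutylamino)ethyl, or a ring amine, such as piperidine in place of dibutylamino, would shift the number beyond the scatter.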